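Cytotoxicity notes: from compound 3 to compound 4

The compounds below may be only part of what the source reports. "The series", "measured", "known", "first", "only" and "open" are said of these compounds alone.

Compound 1 `Cn1cc(SCc2nnc(SCc3ccccc3Cl)n2-c2c(Cl)cccc2Cl)c2ccccc21`: in a toxicity assay on HEK-293T cells (Homo sapiens) for cytotoxicity, read by CCK-8 assay, with a stated time of 48 h (on this read-out higher numbers stand for lower toxicity in this test and lower numbers for higher toxicity in this test), compound 1 gives 49600 nM.
Compound 2 `Cn1cc(SCc2nnc(SCc3cccc(Cl)c3Cl)n2-c2c(Cl)cccc2Cl)c2ccccc21`: in this assay compound 2 reaches only a limit of the assay, > 100000 nM.
Compound 3 `Cn1cc(SCc2nnc(SCc3c(Cl)cccc3Cl)n2-c2c(Cl)cccc2Cl)c2ccccc21`: in this assay compound 3 likewise reaches only a limit of the assay, > 100000 nM.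

Compound 3 therefore stands at the top of the numbers shown, with no number of its own, only a limit; the same holds for compound 2, as the limit of > 100000 nM in this assay, at which 2 of the 3 values shown sit, records. Compound 4 `Cn1cc(SCc2nnc(SCc3ccc(Cl)cc3F)n2-c2c(Cl)cccc2Cl)c2ccccc21` differs from compound 3 in one place: 4-chloro-2-fluorophenyl in place of 2,6-dichlorophenyl on a saturated chain carbon bound to a sulfur.

Of the measured steps, the closest in kind is the swap of the same benzyl ring between compound 2 and compound 3, which gives a step that the two limits leave unreadable from compound 2 to compound 3. The two steps that add a chlorine, an at least 2.0-fold higher number from compound 1 to compound 2 (0.30 log units; that floor lies within the scatter) and an at least 2.0-fold higher number from compound 1 to compound 3 (0.30 log units; that floor lies within the scatter), both run upward but only to the limit. Nothing in these steps shows that a change on this benzyl ring moves this assay beyond the scatter, so no step beyond the scatter is expected. The step from compound 3 to compound 4 is estimated as a number no higher from compound 3 to compound 4 (the limit leaves the size open). Compound 4 is expected to give about 100000 nM, within 35000 nM to 250000 nM.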

Compound 4, half-maximal cytotoxic concentration: 87300 nM
Estimate against measurement, compound 4: 1.1-fold (0.06 log units) above, and the stated range covers the measured number.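

Compound 4 is the only compound shown with a fluorine on this benzyl ring, and in this assay compound 4 gives 87300 nM, a number rather than a limit of the assay. Within the data shown here, the steps of an at least 1.1-fold lower number from compound 3 to compound 4 (0.05 log units; that floor lies within the scatter) and an at least 1.1-fold lower number from compound 2 to compound 4 (0.05 log units; that floor lies within the scatter) give only floors, because both start from a compound with no number of its own: the limit of > 100000 nM in this assay, at which 2 of the 4 values shown sit. Against compound 1, the only other compound with a number, the change gives a 1.8-fold higher number from compound 1 to compound 4 (0.25 log units; within the scatter), so no change of the ring on the saturated chain carbon bound to a sulfur has yet produced a step printed as beyond the scatter.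

From the compounds shown here alone, how far compound 2 and compound 3 actually lie from compound 4 stays open, as neither has a number in this assay. Also open, going by these compounds, is whether an amine or a carboxylic acid on this benzyl ring, in place of the halogens, would move this assay beyond the scatter.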